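This account rests on a few compounds, and the source may have more. Where it says the series, first, only, none or still open, it means among the compounds named here.

Compound 1 `C=C1C(=O)[C@]23C[C@@]1(O)CC[C@H]2c1ccc(O)c(C)c1[C@@H]3Cn1cc(-c2ccc(F)cc2)nn1` and compound 2 `C=C1C(=O)[C@]23C[C@@]1(O)CC[C@H]2c1ccc(OS(=O)(=O)c2ccc(C)cc2)c(C)c1[C@@H]3Cn1cc(-c2ccc(F)cc2)nn1` share one core, while compound 3 `Cc1ccc(-c2cn(C[C@H]3c4c(ccc(O)c4C)[C@@H]4CC[C@@]5(C)C[C@]43CC5=O)nn2)cc1` and compound 4 `Cc1ccc(-c2cn(C[C@H]3c4c(ccc(OS(=O)(=O)c5ccc(C)cc5)c4C)[C@@H]4CC[C@@]5(C)C[C@]43CC5=O)nn2)cc1` share another, and the difference between the two cores is not broken down here. All four belong to a functional assay on SW480 cells (Homo sapiens) for cytotoxicity, read by MTT assay, with a stated time of 4 days; a lower number here means a stronger inhibitor, a higher number a weaker inhibitor. In this assay compound 1 gives 250 nM and compound 2 gives 1630 nM. The change from compound 1 to compound 2 is (4-methylphenyl)sulfonyl in place of hydrogen on an oxygen on an aromatic ring and it produced a 6.5-fold higher number from compound 1 to compound 2 (0.81 log units; beyond the scatter). For compound 3 this assay reports > 20000 nM and that figure is a limit of the assay rather than a number. The change from compound 3 to compound 4 is the same one, namely ((4-methylphenyl)sulfonyl in place of hydrogen on an oxygen on an aromatic ring). Because compound 3 already sits at the limit of > 20000 nM in this assay, at which 1 of the 3 values shown sits, and because this change earlier produced the step of a 6.5-fold higher number from compound 1 to compound 2 (0.81 log units; beyond the scatter) the result for compound 4 is expected to move by a step that the limit leaves unreadable from compound 3 to compound 4 and most likely to come back again only as a limit. Compound 4 is therefore estimated at 40000 nM in this assay. The expected range for compound 4 runs from 15000 nM to 150000 nM.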

Compound 4, half-maximal inhibitory concentration: > 20000 nM
Compound 4 was reported as a limit; the forecaster's own chance of this, stated with the estimate: 85%; the middle value is on the limit's open side.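

Compound 3 and compound 4 both come back from this assay only as limits, so the step between them cannot be read: the limit of > 20000 nM in this assay, at which 2 of the 4 values shown sit.

The compounds shown leave open whether (4-methylphenyl)sulfonyl in place of hydrogen weakens the core of compound 3 as it weakens the core of compound 1, as the numbers for that core show in a 6.5-fold higher number from compound 1 to compound 2 (0.81 log units; beyond the scatter).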